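Extending the benzyl of compound 2 to a 3-phenylprop-2-en-1-yl group

The source may hold more compounds than are shown below. What is called first, only, known or untested is meant among the compounds shown, and "the series" means these compounds.

Of the compounds shown here, two have been measured. Compound 1 `COc1cc(N)c(Cl)cc1NC(=O)C1CCN(Cc2ccc(F)cc2)CC1` gives 0.6 mg/kg in a functional assay on the whole organism for antagonist activity, with Mus musculus as the target; a lower number here means that less compound is needed, a higher number that more compound is needed for the effect. Compound 2 `COc1cc(N)c(Cl)cc1NC(=O)C1CCN(Cc2ccccc2)CC1` gives 0.5 mg/kg in the same assay, and the two numbers sit within the scatter of each other, the step of a 1.2-fold lower number from compound 1 to compound 2 (0.08 log units; within the scatter) being a hydrogen in place of a fluoro on an aromatic carbon. Among the measured compounds shown here, compound 2 therefore stands level with its only neighbour rather than apart from it.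

Compound 3 `COc1cc(N)c(Cl)cc1NC(=O)C1CCN(C/C=C/c2ccccc2)CC1` differs from compound 2 by 2-phenylethenyl in place of phenyl on a saturated chain carbon bound to an amine nitrogen in a ring; cut one bond further out, the change reads benzyl to 3-phenylprop-2-en-1-yl. For the measured compounds named here, no measured step touches this part of the molecule: the single step from compound 1 to compound 2 concerns a substituent on the aromatic ring, not the chain that joins the ring to the amine nitrogen, and it stayed within the scatter. There is thus no basis in the data for expecting a shift in either direction beyond the scatter. Compound 3 is estimated at 0.5 mg/kg in this assay, with a range of 0.2 mg/kg to 1.5 mg/kg, corresponding to an expected step of no change at the digits printed from compound 2 to compound 3 (within the scatter).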

Compound 3, dose for half-maximal effect: > 10 mg/kg
Compound 3: only a limit was reported; the forecaster's own chance of this, stated with the estimate: 5%; middle value at least 20-fold (1.30 log units) from the limit.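

Moving from benzyl to 3-phenylprop-2-en-1-yl on the amine nitrogen in a ring shows that this position, unlike the aromatic substituent examined earlier, is sensitive in this assay: the change of 2-phenylethenyl for phenyl gives an at least 20-fold higher number from compound 2 to compound 3 (1.30 log units; beyond the scatter), and the change of 2-phenylethenyl for 4-fluorophenyl gives an at least 16-fold higher number from compound 1 to compound 3 (1.22 log units; beyond the scatter). The earlier step, a 1.2-fold lower number from compound 1 to compound 2 (0.08 log units; within the scatter), gave no sign of this, so the large shift belongs to the group on the saturated chain carbon and not to the fluoro on the aromatic ring. The true size of both new steps remains unknown, as the reading for compound 3 is a limit of the assay and not a number: the limit of > 10 mg/kg in this assay, at which 1 of the 3 values shown sits.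

The compounds shown leave open whether the double bond or the longer chain accounts for the loss, a question that a saturated 3-phenylpropyl group or a 2-phenylethyl group could separate. They also leave open whether a chain carrying an amine or a carboxylic acid at this position would behave as 2-phenylethenyl does or as phenyl does.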